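Swapping the Amide Aryl Group on a Weakly Antiproliferative Core

This account rests on a few compounds, and the source may have more. Where it says the series, first, only, none or still open, it means among the compounds named here.

Measured compounds:
compound 1, `CCCNc1cc2c(cn1)cc(NC(=O)c1cccc(-c3ccccc3)c1)c(=O)n2C`, with 6000 nM
compound 2, `CN(C)CCNc1cc2c(cn1)cc(NC(=O)c1cc3ccccc3s1)c(=O)n2C`, with 12000 nM

Both numbers come from a functional assay on MCF7 cells (Homo sapiens) for antiproliferative activity, read by MTT assay, with a stated time of 48 h; a higher number here means a weaker inhibitor, a lower number a stronger inhibitor. Compound 1 gives 6000 nM and compound 2 gives 12000 nM; the gap between them lies within the usual scatter of repeated measurements, so neither can be called the stronger or weaker of the two. Both are weak inhibitors on this scale.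

Compound 3, `CN(C)CCNc1cc2c(cn1)cc(NC(=O)c1ccc(N)cc1)c(=O)n2C`, has not yet been measured. It differs from compound 2 in one place: 4-aminophenyl in place of 1-benzothiophen-2-yl on a carbonyl carbon. Going by the values given here, no two measured compounds differ by exactly this change, so no measured step shows what it does. With nothing to go on but the two weak values, the expectation is a step in this assay that stays near the scatter, with no clear direction. Compound 3 is therefore estimated at 12000 nM, within 3500 nM to 40000 nM, which implies an expected step of no change at the digits printed from compound 2 to compound 3 (within the scatter).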

Compound 3, half-maximal inhibitory concentration: 55800 nM
Estimate against measurement, compound 3: 4.7-fold (0.67 log units) below, and the stated range ends below it.
By their numbers in this assay, from the lowest: compounds 1 and 2 (each within the scatter of the next); then compound 3.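

In this assay, the group on the carbonyl carbon can shift the result: with the rest of the molecule unchanged, 4-aminophenyl in place of 1-benzothiophen-2-yl gives a 4.7-fold higher number from compound 2 to compound 3 (0.67 log units; beyond the scatter). This is the first step shown between compounds that differ in one place, and it goes toward a weaker inhibitor, so this position is not indifferent to the group it carries. Nothing at hand explains the rise. The compounds shown leave open whether the higher number goes with the amine on the ring or with the loss of the five-membered ring, a question on which a plain phenyl group at the same carbonyl carbon would bear. Compound 1 differs from both in its chain as well, so it cannot settle this.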